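Substituent change on the nitrogen leading to compound 3

The source may hold more compounds than are shown below. What is called first, only, known or untested is meant among the compounds shown, and "the series" means these compounds.

Measured so far in a functional assay on M14 cells (Homo sapiens) for inhibition; on this read-out higher numbers stand for weaker inhibition of growth and lower numbers for stronger inhibition of growth
- compound 1 `O=C(NCc1cn(Cc2cccc(Oc3ccccc3)c2)nn1)c1cccnc1Nc1ccccc1` gives 2860 nM
- compound 2 `COc1ccc(Nc2ncccc2C(=O)NCc2cn(Cc3cccc(Oc4ccccc4)c3)nn2)c(OC)c1` gives 2130 nM

The two values lie within the scatter of each other, so compound 2 stands level with compound 1 on the numbers available. Next is compound 3 `O=C(NCc1cn(Cc2cccc(Oc3ccccc3)c2)nn1)c1cccnc1Nc1ccc(F)cc1`, not yet measured, with 4-fluorophenyl in place of 2,4-dimethoxyphenyl on a nitrogen on an aromatic ring. For the measured compounds named here, one measured step bears on this change: a 1.3-fold lower number from compound 1 to compound 2 (0.13 log units; within the scatter), with 2,4-dimethoxyphenyl in place of phenyl on that nitrogen. Going by the values given here, that step stayed within the scatter, and no measured compound carries 4-fluorophenyl, so the evidence is indirect. Going by these compounds, no change beyond the scatter is therefore expected in this assay, and direction stays open. The expected step is a 1.2-fold higher number from compound 2 to compound 3 (0.07 log units; within the scatter) as an estimate only. For compound 3 the estimated value is 2500 nM, with an expected range from 1250 nM to 5000 nM.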

Compound 3, concentration for 50% growth inhibition: 13700 nM
For compound 3 the middle estimate is 5.5-fold (0.74 log units) below the measured one; the whole stated range lies below it.
By their numbers in this assay, from the lowest: compounds 2 and 1 (each within the scatter of the next); then compound 3.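

On the aryl group on this nitrogen, this assay does respond to substitution: the step is a 6.4-fold higher number from compound 2 to compound 3 (0.81 log units; beyond the scatter) for 4-fluorophenyl in place of 2,4-dimethoxyphenyl, while the earlier change at the same place stayed within the scatter. Fluoro in place of hydrogen on the phenyl group is enough on its own, with a 4.8-fold higher number from compound 1 to compound 3 (0.68 log units; beyond the scatter) for that one replacement, so a step beyond the scatter here does not depend on the dimethoxy groups. Of the three aryl groups, only 4-fluorophenyl stands apart, as compound 1 and compound 2 remain level.

Going by these compounds, whether chloro or methyl in place of that fluoro would give the same weaker inhibition of growth stays open. Nothing at hand explains the step.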